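From furan-2-yl to methyl on a shared core

The compounds below may be only part of what the source reports. "The series", "measured", "known", "first", "only" and "open" are said of these compounds alone.

In a functional assay on HCT-116 cells (Homo sapiens), read by MTT assay, with a stated time of 3 days (on this read-out higher numbers stand for weaker inhibition and lower numbers for stronger inhibition), compound 3 `c1coc(-c2ncnc3[nH]cc(Sc4cccs4)c23)c1` gives 19500 nM, the higher of the two true numbers available. The other number belongs to compound 2 `c1csc(Sc2c[nH]c3ncnc(-c4cccs4)c23)c1`, at 5060 nM. Compound 1 `Nc1ncnc2[nH]cc(Sc3cccs3)c12` gives only a limit, > 50000 nM.

Compound 4 `Cc1ncnc2[nH]cc(Sc3cccs3)c12` keeps the shared core and the thiophene-bearing sulfur side of compound 3, but has methyl in place of furan-2-yl on an aromatic carbon.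

Three measured changes at this same carbon bear on the swap. The step of a 3.9-fold higher number from compound 2 to compound 3 (0.59 log units; beyond the scatter) compares two ring groups. The steps of an at least 9.8-fold lower number from compound 1 to compound 2 (0.99 log units; beyond the scatter) and an at least 2.5-fold lower number from compound 1 to compound 3 (0.40 log units; beyond the scatter) each replace amino, a group without a ring, with a ring group, and both moved toward stronger inhibition. Methyl also has no ring, so removing the furan-2-yl ring is expected to reverse part of the gain seen in the step of an at least 2.5-fold lower number from compound 1 to compound 3 (0.40 log units; beyond the scatter). The expected change is modest and toward weaker inhibition: a 2.2-fold higher number from compound 3 to compound 4 (0.33 log units; beyond the scatter). For compound 4 the estimate is 42000 nM, with an expected range from 18000 nM to 100000 nM.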

Compound 4, half-maximal inhibitory concentration: 29100 nM
Estimate against measurement, compound 4: 1.4-fold (0.16 log units) above; the range from low to high includes it.
By their numbers in this assay, from the lowest: compound 2; then compounds 3 and 4 (each within the scatter of the next). At a limit, above all of these: compound 1.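

In this assay, methyl in place of furan-2-yl on an aromatic carbon is a 1.5-fold higher number from compound 3 to compound 4 (0.17 log units; within the scatter), so at this carbon these two groups cannot be told apart, although one is a ring and the other is not. Thiophen-2-yl does stand apart from methyl, with a 5.8-fold higher number from compound 2 to compound 4 (0.76 log units; beyond the scatter), so among the groups shown, having a ring here is not enough on its own to separate a compound from methyl. Methyl in place of amino on an aromatic carbon is an at least 1.7-fold lower number from compound 1 to compound 4 (0.23 log units; that floor lies within the scatter), and only the floor of this step is known. Compound 1 carries a limit: the limit of > 50000 nM in this assay, at which 1 of the 4 values shown sits.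

From the compounds shown here alone, it remains open whether thiophen-2-yl is alone among ring groups at this carbon, which a phenyl or pyridyl ring would test. The compounds shown also leave open how an ethyl group, a longer chain or a methoxy group would behave here.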